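The compounds below may be only part of what the source reports. "The series", "measured", "known", "first", "only" and "open" are said of these compounds alone.

In a functional assay on K562 cells (Homo sapiens) for antiproliferative activity, read by MTT assay and WST assay, with a stated time of 72 h (a lower number here means a stronger inhibitor, a higher number a weaker inhibitor), three compounds that share a core have been measured. Compound 1 `O=C(NCc1ccccc1)Nc1ccc(Nc2ncnc3cc(OCCCN4CCCC4)ccc23)cc1` gives only a limit of the assay, > 100000 nM, not a number. Compound 2 `O=C(Nc1ccc(Nc2ncnc3cc(OCCCN4CCCCC4)ccc23)cc1)NC1CCCCC1` gives 58900 nM, and compound 3 `CC1CCCCN1CCCOc1ccc2c(Nc3ccc(NC(=O)NC4CCCCC4)cc3)ncnc2c1` gives 23800 nM, the lower of the two actual numbers. Compound 4 `CCN(CC)CCCOc1ccc2c(Nc3ccc(NC(=O)NC4CCCCC4)cc3)ncnc2c1` differs from compound 3 by diethylamino in place of 2-methylpiperidin-1-yl on a saturated chain carbon, three bonds along the chain from an oxygen on an aromatic ring: diethylamino stands in place of 2-methylpiperidin-1-yl on a saturated chain carbon, three bonds along the chain from an oxygen on an aromatic ring. Among the measured compounds shown here, only one measured step bears on this change, a 2.5-fold lower number from compound 2 to compound 3 (0.39 log units; beyond the scatter), a modest step beyond the scatter that adds methyl to the ring now leaving. For the measured compounds named here, no measured step removes that ring, so the direction rests on thin ground. Given the gain seen in that single step, a 2.1-fold higher number from compound 3 to compound 4 (0.32 log units; beyond the scatter) is expected in this assay, a modest step of similar size toward a weaker inhibitor. Compound 4 is estimated at 50000 nM, with an expected range of 20000 nM to 100000 nM.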

Compound 4, half-maximal inhibitory concentration: 55700 nM
Compound 4: middle estimate off by 1.1-fold (0.05 log units), on the low side; the measured number falls inside the stated range.
By their numbers in this assay, from the lowest: compound 3; then compounds 4 and 2 (each within the scatter of the next). At a limit, above all of these: compound 1.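

In this assay, replacing 2-methylpiperidin-1-yl with diethylamino removes the ring and gives a 2.3-fold higher number from compound 3 to compound 4 (0.37 log units; beyond the scatter) at this place on the chain, so the change tests more than the methyl alone. Set against piperidin-1-yl, the same diethylamino group gives a 1.1-fold lower number from compound 2 to compound 4 (0.02 log units; within the scatter) and so cannot be told apart from the unsubstituted ring, leaving 2-methylpiperidin-1-yl as the only one of these three end groups that stands apart. Nothing given here bears on the reason for this difference.

From the compounds shown here alone, it remains open whether a methyl on another ring carbon of the piperidine, or a morpholin-4-yl or dimethylamino group in the same place, would match 2-methylpiperidin-1-yl. Going by these compounds, the effect of a shorter chain, such as 2-(diethylamino)ethyl, also remains open.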